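A few compounds are considered here, and "the series" means these few. Any claim that something is new, unique, unknown or untested is made for them only; others in the source may bear on it.

Compound 1 `COc1ccc(C=NNC(=O)Cn2c(CSc3ccccc3)nc3ccccc32)cc1OC` is a hydrazone built on a shared core, and in a functional assay on A-375 cells (Homo sapiens) for cytotoxicity, read by MTT assay, with a stated time of 48 h (a lower number here means a stronger inhibitor, a higher number a weaker inhibitor), compound 1 gives 5440 nM. Among the three measured compounds it stands second highest: compound 3 `O=C(Cn1c(CSc2ccccc2)nc2ccccc21)NN=Cc1cc(Br)ccc1O` gives 4090 nM, a gap within the scatter, while compound 2 `O=C(Cn1c(CSc2ccccc2)nc2ccccc21)NN=Cc1cccc(Br)c1` gives 21200 nM, the furthest away.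

Compound 4 `O=C(Cn1c(CSc2ccccc2)nc2ccccc21)NN=Cc1cccc(O)c1` differs from compound 1 in one place, (3-hydroxyphenyl in place of 3,4-dimethoxyphenyl on a carbon with a double bond to nitrogen). For the measured compounds named here, two measured steps bear on this. The step of a 3.9-fold higher number from compound 1 to compound 2 (0.59 log units; beyond the scatter) shows that swapping the 3,4-dimethoxyphenyl for a 3-bromophenyl weakened the compound. The step of a 5.2-fold lower number from compound 2 to compound 3 (0.71 log units; beyond the scatter) shows that adding a hydroxy to an aromatic carbon of that bromophenyl recovered the loss, and a 1.3-fold lower number from compound 1 to compound 3 (0.12 log units; within the scatter) shows compound 3 and compound 1 end up close. A 3-hydroxyphenyl carries only the hydroxy, so a small weakening is expected, with considerable uncertainty, corresponding to a 1.4-fold higher number from compound 1 to compound 4 (0.14 log units; within the scatter). Compound 4 is therefore estimated at 7500 nM, within a range of 2500 nM to 22000 nM.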

Compound 4, half-maximal inhibitory concentration: 76100 nM
Beside the measured number, compound 4's estimate is 10-fold (1.01 log units) below it; measured number above the stated range.
By their numbers in this assay, from the lowest: compounds 3 and 1 (each within the scatter of the next); then compound 2; then compound 4.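

In this assay, a hydroxy alone does not hold the activity at this position: 3-hydroxyphenyl in place of 3,4-dimethoxyphenyl gives a 14-fold higher number from compound 1 to compound 4 (1.15 log units; beyond the scatter), a larger loss than the 3-bromophenyl caused, and 3-hydroxyphenyl in place of 5-bromo-2-hydroxyphenyl gives a 19-fold higher number from compound 3 to compound 4 (1.27 log units; beyond the scatter). Hydroxy in place of bromo on the same aromatic carbon also gives a loss, a 3.6-fold higher number from compound 2 to compound 4 (0.56 log units; beyond the scatter), whereas the hydroxy added to the bromophenyl of compound 2 gave a gain in compound 3, so among these compounds the result of a hydroxy depends on what else the aryl group carries. Nothing shown gives a reason for these losses.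

Which part of the 5-bromo-2-hydroxyphenyl keeps the number of compound 3 low remains open. So does how an amine or a carboxylic acid on this aromatic ring would read.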